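The source may report more compounds than this note shows. Statements on the series, on what has been measured and on what is new or still open speak of the compounds shown alone.

In an assay (Sus scrofa) for displacement of a labelled ligand from Type-2 angiotensin II receptor (Homo sapiens) (a higher number here means a weaker inhibitor, a lower number a stronger inhibitor), compound 1 `CCCCOC(=O)NS(=O)(=O)c1sc(CC(C)C)cc1-c1ccc(Cn2cnc3cccnc32)cc1` gives 7.1 nM and compound 2 `CCCCOC(=O)NS(=O)(=O)c1sc(CC(C)C)cc1-c1ccc(Cn2c(CC)nc3ccccc32)cc1` gives 3.2 nM. Compound 2 thus has the lower of the two numbers, with a 2.2-fold lower number from compound 1 to compound 2 (0.35 log units; beyond the scatter) separating it from compound 1. Compound 3 `CCCCOC(=O)NS(=O)(=O)c1sc(CC(C)C)cc1-c1ccc(Cn2cnc3ccccc32)cc1` keeps the shared core of compound 2 but carries hydrogen in place of ethyl on an aromatic carbon, hydrogen in place of ethyl on an aromatic carbon. Going by the values given here, no measured pair isolates this change: the only step on record, a 2.2-fold lower number from compound 1 to compound 2 (0.35 log units; beyond the scatter), swaps the whole two-ring group at this position and adds the ethyl together, so it bears on the question but cannot separate the two. Since that combined change moved the number only modestly, the loss of the ethyl alone is expected to weaken binding somewhat, as a 2.5-fold higher number from compound 2 to compound 3 (0.40 log units; beyond the scatter). Compound 3 is therefore estimated at 8 nM in this assay, with a likely range from 2.5 nM to 30 nM.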

Compound 3, inhibition constant: 4 nM
The estimate for compound 3 lay 2.0-fold (0.30 log units) above the measured number, within the range that was stated.
By their numbers in this assay, from the lowest: compounds 2, 3 and 1 (each within the scatter of the next, the first and the last beyond it).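

The exchange of ethyl for hydrogen on this aromatic carbon between two ring nitrogen atoms can now be read on its own in this assay (a 1.3-fold higher number from compound 2 to compound 3 (0.10 log units; within the scatter)), so compound 2 and compound 3 cannot be told apart here. The ring exchange can also be read without the ethyl (a 1.8-fold lower number from compound 1 to compound 3 (0.25 log units; within the scatter)), so neither part of the earlier combined step is a clear difference by itself, although together they lie just beyond the scatter (a 2.2-fold lower number from compound 1 to compound 2 (0.35 log units; beyond the scatter)). Nothing measured here explains these numbers.

Only hydrogen and ethyl are shown on this carbon, so the effect of a longer chain such as butyl, an amine or a carboxylic acid there remains open. Also open, going by these compounds, is how the core of compound 1 would compare if it carried the ethyl.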